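A few compounds are considered here, and "the series" means these few. Any claim that something is new, unique, unknown or untested is made for them only; others in the source may bear on it.

Measured in a functional assay on B16 cells (Mus musculus) for cytotoxicity, read by MTT assay, with a stated time of 48 h; on this read-out lower numbers stand for stronger inhibition and higher numbers for weaker inhibition:
- compound 1 `O=C(Nc1cccc(-c2cn(Cc3ccccc3)nn2)c1)c1cn(Cc2ccccc2)nn1` gives 4500 nM
- compound 2 `CCOC(=O)Cn1cc(-c2cccc(NC(=O)c3cn(Cc4ccccc4)nn3)c2)nn1` gives 21000 nM

Compound 2 has the higher of the two numbers. Compound 3 `CC(=O)OCCn1cc(-c2cccc(NC(=O)c3cn(Cc4ccccc4)nn3)c2)nn1` keeps the same atoms, joined differently: acetoxymethyl in place of ethoxycarbonyl on a saturated chain carbon bound to an aromatic nitrogen. For the measured compounds named here, the only measured step at this place is a 4.7-fold higher number from compound 1 to compound 2 (0.67 log units; beyond the scatter), and it replaces phenyl, so it only loosely bears on this swap. No step beyond the scatter is expected in this assay, and no direction can be favoured. The expected change is a 1.1-fold lower number from compound 2 to compound 3 (0.04 log units; within the scatter). The estimated value for compound 3 is 19000 nM, with a range of 8000 nM to 45000 nM.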

Compound 3, half-maximal inhibitory concentration: 25100 nM
The estimate for compound 3 lay 1.3-fold (0.12 log units) below the measured number; the measured number falls inside the stated range.
By their numbers in this assay, from the lowest: compound 1; then compounds 2 and 3 (each within the scatter of the next).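

In this assay, the swap from ethoxycarbonyl to acetoxymethyl on a saturated chain carbon bound to an aromatic nitrogen gives a 1.2-fold higher number from compound 2 to compound 3 (0.08 log units; within the scatter), so reversing the ester linkage with the same atoms leaves the read-out unchanged. Acetoxymethyl in place of phenyl gives a 5.6-fold higher number from compound 1 to compound 3 (0.75 log units; beyond the scatter), so the higher number seen with ethoxycarbonyl recurs with a second ester group. No measurement here accounts for either result. Open, going by these compounds, is whether a carboxylic acid, an amine or a longer chain at this place would give a number nearer that of compound 1.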